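A few compounds are considered here, and "the series" means these few. Any claim that something is new, unique, unknown or untested is made for them only; others in the source may bear on it.

Compound 1 `Cc1ccc(-c2ncccn2)c(C(=O)N2CC3(CC3)C[C@H]2CNc2cc(C(F)(F)F)ccn2)c1` gives 7.8 in a functional assay on HEK293 cells for antagonist activity at Orexin receptor type 2 (Homo sapiens), read by FLIPR and calcium flux; on this read-out higher numbers stand for higher potency (the scale is a negative logarithm) and lower numbers for lower potency. Compound 2 `Cc1ccc(-c2ncccn2)c(C(=O)N2CC3(CC3)C[C@H]2CNc2ccc(Cl)cn2)c1` reaches only the limit < 5 in this assay, and so stands on a limit rather than a number (the limit of < 5 in this assay, at which 1 of the 2 values shown sits). Compound 3 `Cc1ccc(-c2ncccn2)c(C(=O)N2CC3(CC3)C[C@H]2CNc2ccc(C(F)(F)F)cn2)c1` differs from compound 2 by a trifluoromethyl in place of chloro on an aromatic carbon. Among the compounds with values here, the only measured step, a number at least 2.80 log units lower from compound 1 to compound 2 (beyond the scatter), changed both the group and its ring position, so it bears only loosely here. Compound 3 is therefore expected to gain somewhat, a step of a number at least 1.00 log units higher from compound 2 to compound 3 (beyond the scatter), with an estimated 6 in this assay, between 4.8 and 7.4.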

Compound 3, negative logarithm of the antagonist equilibrium constant: 6.6
Beside the measured number, compound 3's estimate is 0.60 log units below it; the measured number falls inside the stated range.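

Compound 2 stands on a limit, not a number: the limit of < 5 in this assay, at which 1 of the 3 values shown sits. With the ring position held fixed, trifluoromethyl in place of chloro is enough to change the result in this assay, giving a number at least 1.60 log units higher from compound 2 to compound 3 (beyond the scatter). With the group held fixed, 5-(trifluoromethyl)pyridin-2-yl in place of 4-(trifluoromethyl)pyridin-2-yl gives a number 1.20 log units lower from compound 1 to compound 3 (beyond the scatter), so the group and its ring position each matter on their own. Still open, as far as these compounds go, is how other groups on this ring carbon, such as a nitrile or a methyl, would compare with trifluoromethyl and chloro.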